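Swapping Piperidine for a Sulfonylated Pyrrolidine

The source may report more compounds than this note shows. Statements on the series, on what has been measured and on what is new or still open speak of the compounds shown alone.

Compound 1 `CN1CCN(c2ccc(Nc3ncc4nc(Nc5ccc(F)cc5)n([C@@H]5CCCNC5)c4n3)cc2)CC1` and compound 2 `CN1CCN(c2ccc(Nc3ncc4nc(Nc5ccccc5)n([C@@H]5CCN(S(=O)(=O)C6CC6)C5)c4n3)cc2)CC1` share the same core and differ at two places: the ring attached to the aromatic nitrogen and the presence of a fluorine on the anilino ring. In a functional assay on HCC827 cells (Homo sapiens) for antiproliferative activity, read by MTT assay, with a stated time of 72 h (on this read-out lower numbers stand for stronger inhibition and higher numbers for weaker inhibition), compound 1 gives 120 nM, the higher of the two values recorded so far, while compound 2 gives 0.88 nM, a gap that lies well beyond the scatter of the measurement.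

Compound 3 `CN1CCN(c2ccc(Nc3ncc4nc(Nc5ccc(F)cc5)n([C@H]5CCN(S(=O)(=O)C6CC6)C5)c4n3)cc2)CC1` has not yet been measured. It differs from compound 1 in a single place: 1-(cyclopropylsulfonyl)pyrrolidin-3-yl in place of piperidin-3-yl on an aromatic nitrogen. The entering group is the same one that compound 2 carries, so compound 3 combines the fluorinated anilino group of compound 1 with the sulfonylated pyrrolidine of compound 2. Going by the values given here, no step between measured compounds isolates this change, so the expectation rests on the two values alone. A large gain is expected because compound 2 gives 0.88 nM. The estimated step is a 40-fold lower number from compound 1 to compound 3 (1.60 log units; beyond the scatter). Compound 3 is expected to give 3 nM, within a range from 0.8 nM to 15 nM.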

Compound 3, half-maximal inhibitory concentration: 7.5 nM
Compound 3: middle estimate off by 2.5-fold (0.40 log units), on the low side; measured number inside the range.
By their numbers in this assay, from the lowest: compound 2; then compound 3; then compound 1.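

Going by these compounds alone, this is the first step that changes only the ring on the aromatic nitrogen while the fluorinated anilino group stays fixed: in this assay, it gives a 16-fold lower number from compound 1 to compound 3 (1.20 log units; beyond the scatter). The position therefore accepts the larger 1-(cyclopropylsulfonyl)pyrrolidin-3-yl group, and activity improves well beyond the scatter even though the hydrogen-bond donor of piperidin-3-yl is gone, so the gain does not depend on keeping that donor. No measurement shown here accounts for the size of this step.

This single swap changes the ring size and adds the sulfonyl group together, so a bare pyrrolidin-3-yl or a 1-(cyclopropylsulfonyl)piperidin-3-yl group would be needed to tell how much each part contributes, and a smaller sulfonyl such as methylsulfonyl would test whether the cyclopropyl ring matters. Compound 2 and compound 3 differ both in the fluorine and in the configuration of their stereocentre, so the values of this pair cannot assign any difference to either feature alone.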